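Compound 2 to compound 3: a working estimate

The source may hold more compounds than are shown below. What is called first, only, known or untested is meant among the compounds shown, and "the series" means these compounds.

In a functional assay on SW480 cells (Homo sapiens) for antiproliferative activity, read by MTT assay, with a stated time of 48 h (a lower number here means a stronger inhibitor, a higher number a weaker inhibitor), compound 1 (`CC(C)=CCC[C@]1(C)/C=C/[C@@H](OC(=O)C=C(C)C)[C@](C)(O)/C=C/C(=O)/C(CCl)=C\C1`) gives 390 nM, and compound 2 (`CSC(=S)OC/C1=C/C[C@](C)(CCC=C(C)C)/C=C/[C@@H](OC(=O)C=C(C)C)[C@](C)(O)/C=C/C1=O`) gives 390 nM. Going by the values given here, compound 2 therefore stands level with compound 1, its only measured neighbour.

The next structure is compound 3 (`CO/N=C/C1=C/C[C@](C)(CCC=C(C)C)/C=C/[C@@H](OC(=O)C=C(C)C)[C@](C)(O)/C=C/C1=O`). The change is a group of 4 heavy atoms (2 carbon, 1 nitrogen, 1 oxygen; no ring) in place of a group of 6 heavy atoms (3 carbon, 1 oxygen, 2 sulfur; no ring), on a double-bonded ring carbon. That ring carbon lies three ring bonds from the ring atom that bears a 4-methylpent-3-en-1-yl group.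

Among the compounds with values here, only one measured step bears on this change: no change at the digits printed from compound 1 to compound 2 (within the scatter). It lies within the scatter and also involved the substituent on this ring carbon. That step kept the saturated chain carbon, whereas the group entering compound 3 has no such carbon on the ring, so the parallel is only partial. With a single step as evidence, the range has to stay wide. No move beyond the scatter is expected in this assay, and the expected step is a 1.2-fold higher number from compound 2 to compound 3 (0.09 log units; within the scatter). The estimate for compound 3 is 480 nM, with an expected range from 150 nM to 1500 nM.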

Compound 3, half-maximal inhibitory concentration: 2630 nM
Estimate against measurement, compound 3: 5.5-fold (0.74 log units) below; the whole stated range lies below it.
By their numbers in this assay, from the lowest: compounds 1 and 2 (each within the scatter of the next); then compound 3.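

In this assay, this double-bonded ring carbon proves not to be indifferent to its substituent: the group of 4 heavy atoms gives a 6.7-fold higher number from compound 2 to compound 3 (0.83 log units; beyond the scatter), and the same group gives a 6.7-fold higher number from compound 1 to compound 3 (0.83 log units; beyond the scatter). The earlier pair showed only that a chlorine atom and the sulfur-containing group, each on a saturated chain carbon, could be exchanged without separating the two numbers; that tolerance does not carry over to compound 3, which has no such carbon on the ring. Nothing available accounts for the higher number in compound 3.

With a single compound on this side of the comparison, the loss of the saturated chain carbon and the identity of the nitrogen- and oxygen-containing group cannot be separated, so neither can be held responsible for the step. An amine on a saturated chain carbon would test the first of these, while a longer chain in place of the methyl on the oxygen of compound 3 would test whether the number at this position moves with the size of the entering group.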